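This account rests on a few compounds, and the source may have more. Where it says the series, first, only, none or still open, it means among the compounds named here.

Measured so far in an ADME assay on PANC-1 cells (Homo sapiens) for cytotoxicity, read by MTT assay, with a stated time of 48 h; a higher number here means a weaker inhibitor of growth, a lower number a stronger inhibitor of growth:
Compound 1 `O=C(/C=C\c1ccc([N+](=O)[O-])cc1)N1N=C(c2ccncc2)OC1c1c[nH]c2ccccc12` gives > 30 ug/mL, a limit of the assay.
Compound 2 `O=C(/C=C\c1ccc(F)cc1)N1N=C(c2ccncc2)OC1c1c[nH]c2ccccc12` gives > 30 ug/mL, a limit of the assay.
Compound 3 `O=C(/C=C\c1cccc(Cl)c1Cl)N1N=C(c2ccncc2)OC1c1c[nH]c2ccccc12` gives > 30 ug/mL, a limit of the assay.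

Compound 1 stands at a limit only, so its place among the measured compounds cannot be fixed. The steps a step that the two limits leave unreadable from compound 1 to compound 2, a step that the two limits leave unreadable from compound 1 to compound 3 and a step that the two limits leave unreadable from compound 2 to compound 3 are all unreadable. The one thing the data show is the limit of > 30 ug/mL in this assay, at which 3 of the 3 values shown sit: every value sits there, and none of the groups tried so far on the double-bonded chain carbon has brought a compound into the range where a number is read.

Compound 4 `O=C(/C=C/c1c(Cl)cccc1Cl)N1N=C(c2ccncc2)OC1c1c[nH]c2ccccc12` differs from compound 1 as follows. 2-(2,6-dichlorophenyl)ethenyl in place of 2-(4-nitrophenyl)ethenyl on a carbonyl carbon A related exchange of the aryl group, to 2,3-dichlorophenyl in compound 3, gave no readable result either. Within the data shown here, no measured step therefore points in any direction, and compound 4 is expected to remain at the limit as well, so that the expected step that the limit leaves unreadable from compound 1 to compound 4 would again be unreadable. The estimate for compound 4 in this assay is 40 ug/mL, with a range from 15 ug/mL to 100 ug/mL.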

Compound 4, concentration for 50% growth inhibition: > 30 ug/mL
Compound 4: only a limit was reported; the forecaster's own chance of this, stated with the estimate: 80%; the middle value is on the limit's open side.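

Compound 4 gives > 30 ug/mL in this assay, a limit and not a number. Its steps from compound 1, compound 2 and compound 3 cannot be read: the limit of > 30 ug/mL in this assay, at which 4 of the 4 values shown sit. Going by these compounds, what stays open is how far each compound lies past this limit, and so whether exchanging these aryl groups changes growth inhibition at all.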